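Benzylthio variation on a pyrazolylamidine sulfonamide scaffold

A few compounds are considered here, and "the series" means these few. Any claim that something is new, unique, unknown or untested is made for them only; others in the source may bear on it.

Measured compounds:
compound 1 `Cc1cc(-c2ccccc2)n(/C(N)=N/S(=O)(=O)c2cc(C)c(Cl)cc2SCc2cccc3ccccc23)n1`, 170000 nM
compound 2 `Cc1ccc(CSc2cc(Cl)c(C)cc2S(=O)(=O)/N=C(\N)n2nc(C)cc2-c2ccccc2)cc1`, 89000 nM
compound 3 `Cc1cc(S(=O)(=O)/N=C(\N)n2nccc2-c2ccccc2)c(SCc2cccc(Cl)c2)cc1Cl`, 88000 nM

In a functional assay on MCF7 cells (Homo sapiens) for cytotoxicity, read by MTT assay, with a stated time of 72 h (on this read-out lower numbers stand for stronger inhibition and higher numbers for weaker inhibition), compound 2 gives 89000 nM, which is the second highest of the three numbers; its nearest neighbour is compound 3 at 88000 nM, a value within the scatter of compound 2, and its furthest is compound 1, with the step of a 1.9-fold lower number from compound 1 to compound 2 (0.28 log units; within the scatter). Compound 4 `Cc1cc(-c2ccccc2)n(/C(N)=N/S(=O)(=O)c2cc(C)c(Cl)cc2SCc2cccc(C(F)(F)F)c2)n1` has not yet been measured. It differs from compound 2 by 3-(trifluoromethyl)phenyl in place of 4-methylphenyl on a saturated chain carbon bound to a sulfur. For the measured compounds named here, the only measured step at the same place, from compound 1 to compound 2, stayed within the scatter, and no other step bears on this change, so no step beyond the scatter is expected in this assay. Compound 4 is therefore estimated at 90000 nM, with a range from 40000 nM to 200000 nM, corresponding to an expected step of a 1.0-fold higher number from compound 2 to compound 4 (0.00 log units; within the scatter).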

Compound 4, half-maximal inhibitory concentration: 41000 nM
Estimate against measurement, compound 4: 2.2-fold (0.34 log units) above; the range from low to high includes it.
By their numbers in this assay, from the lowest: compound 4; then compounds 3, 2 and 1 (each within the scatter of the next).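

At the saturated chain carbon bound to a sulfur, a change of aryl group now moves the number in this assay beyond the scatter, which the earlier step at this place did not show. 3-(trifluoromethyl)phenyl in place of 4-methylphenyl gives a modest step (a 2.2-fold lower number from compound 2 to compound 4 (0.34 log units; beyond the scatter)), and in place of naphthalen-1-yl a modest step as well (a 4.1-fold lower number from compound 1 to compound 4 (0.62 log units; beyond the scatter)). Nothing at hand accounts for either step. Open remains whether the trifluoromethyl group itself or its place on the ring matters, and what an amine or a carboxylic acid would give there.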